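Thiosemicarbazone series: taking the ring iodine away

This account rests on a few compounds, and the source may have more. Where it says the series, first, only, none or still open, it means among the compounds named here.

Three analogues on a shared core have been measured in a functional assay on MCF7 cells (Homo sapiens) for cytotoxicity, read by MTT assay, with a stated time of 48 h; on this read-out lower numbers stand for stronger inhibition and higher numbers for weaker inhibition. Compound 1 `C/C(=N/NC(=S)Nc1ccccc1[N+](=O)[O-])c1ccccn1` gives 5.7 nM, compound 2 `C/C(=N/NC(=S)Nc1cccc(I)c1)c1ccccn1` gives 45 nM, and compound 3 `C/C(=N/NC(=S)Nc1ccc(I)cc1)c1ccccn1` gives 6.61 nM. Compound 3 thus holds the second highest of the three numbers; its value and that of compound 1 lie within the scatter of each other, while compound 2 stands well beyond it with the higher number. Compound 4 `C/C(=N/NC(=S)Nc1ccccc1)c1ccccn1` has not yet been run. It differs from compound 3 in one place: hydrogen in place of iodo on an aromatic carbon. Going by the values given here, no step between measured compounds covers this change, so the expectation rests on the spread seen so far. A modest rise in the number is expected for compound 4, near the edge of the scatter, as the step of a 2.3-fold higher number from compound 3 to compound 4 (0.36 log units; beyond the scatter). Compound 4 is accordingly estimated at 15 nM, with a range of 5 nM to 50 nM.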

Compound 4, half-maximal inhibitory concentration: 0.18 nM
Compound 4: the middle estimate sits 83-fold (1.92 log units) above what was measured, and the stated range ends above it.
By their numbers in this assay, from the lowest: compound 4; then compounds 1 and 3 (each within the scatter of the next); then compound 2.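

In this assay, hydrogen in place of iodo on an aromatic carbon, para to a large group, gives a 37-fold lower number from compound 3 to compound 4 (1.56 log units; beyond the scatter) and so far exceeds the spread among the substituted analogues. The other two replacements run the same way, with iodo giving way to hydrogen in a 250-fold lower number from compound 2 to compound 4 (2.40 log units; beyond the scatter) and nitro giving way to hydrogen in a 32-fold lower number from compound 1 to compound 4 (1.50 log units; beyond the scatter), so none of the three ring substituents shown is needed for a low number on this read-out. No measurement shown accounts for the size of these steps.

On these data alone, whether a fluoro, methyl or amine group on this ring would keep the number near that of compound 4 remains open.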